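This account rests on a few compounds, and the source may have more. Where it says the series, first, only, none or still open, it means among the compounds named here.

In a functional assay on THP-1 cells (Homo sapiens) for inhibition, with a stated time of 48 h, tested at 50 uM (on this read-out lower numbers stand for less inhibition of growth and higher numbers for more inhibition of growth at the one concentration tested), compound 1 (`C=C[C@@](C)(/C=C/c1ccc(OC(=O)CCCC)cc1)CCC=C(C)C`) gives 15% and compound 2 (`C=C[C@@](C)(/C=C/c1ccc(OC(=O)CCCCC)cc1)CCC=C(C)C`) gives 54%, the higher of the two numbers. Compound 3 (`C=C[C@@](C)(/C=C/c1ccc(OC(=O)CCCCCCC)cc1)CCC=C(C)C`) differs from compound 2 by ethyl in place of hydrogen on a saturated chain carbon, five bonds along the chain from a carbonyl carbon, a further extension of the same chain. Within the data shown here, the only measured step bearing on this change is a number 39 percentage points higher from compound 1 to compound 2 (beyond the scatter), which is large and beyond the scatter. One step cannot show how far a rise continues, so the expected move is upward but smaller: a number 16 percentage points higher from compound 2 to compound 3 (beyond the scatter). Compound 3 is estimated at 70%, with an expected range of 45% to 95%.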

Compound 3, percent growth inhibition at one concentration: 62%
Beside the measured number, compound 3's estimate is 8 percentage points above it; the measured number falls inside the stated range.
By their numbers in this assay, from the lowest: compound 1; then compounds 2 and 3 (each within the scatter of the next).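

In this assay the ethyl extension, five bonds along the chain from a carbonyl carbon, gives a number 8 percentage points higher from compound 2 to compound 3 (within the scatter), so the rise of a number 39 percentage points higher from compound 1 to compound 2 (beyond the scatter) is not shown to continue at this position. The whole change, propyl in place of hydrogen four bonds along the chain from a carbonyl carbon, still gives a number 47 percentage points higher from compound 1 to compound 3 (beyond the scatter), a gain that compound 2 and compound 3 share. Nothing available explains this dependence on chain length.

From the compounds shown here alone, whether a longer chain keeps the level of compound 3 or loses it remains open. So does the effect of an amine or a carboxylic acid at the chain end.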